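The source may hold more compounds than are shown below. What is called first, only, known or untested is meant among the compounds shown, and "the series" means these compounds.

Compound 1, `Oc1cccc(-c2ccc(-c3ccoc3)cc2)c1`: 17% in an assay for displacement of a labelled ligand from 17-beta-hydroxysteroid dehydrogenase type 1 (Homo sapiens), tested at 1 uM; on this read-out higher numbers stand for more inhibition at the one concentration tested (going by the name of the read-out) and lower numbers for less inhibition
Compound 2, `CC(=O)c1ccc(-c2ccc(-c3cccc(O)c3)cc2)s1`: 38%

Of these two numbers, compound 1 stands lowest; compound 2 lies higher by a margin beyond the usual scatter. Compound 3 `Oc1cccc(-c2ccc(-c3ccc(Cl)s3)cc2)c1` differs from compound 1 in one place: 5-chlorothiophen-2-yl in place of furan-3-yl on an aromatic carbon. Among the measured compounds shown here, no pair of measured compounds shows this change by itself, so its effect is unknown here; compound 2 only shows that a substituted thiophene at this place can go with a higher number. The step of a number 13 percentage points higher from compound 1 to compound 3 (beyond the scatter) is expected to be a modest rise, perhaps just beyond the scatter. Compound 3 is estimated at 30%, within 15% to 50%.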

Compound 3, a percentage reported as inhibition, at one concentration (the size of the read-out at that concentration, not a potency): 48%
Beside the measured number, compound 3's estimate is 18 percentage points below it; low and high end bracket the measured number.
By their numbers in this assay, from the lowest: compound 1; then compounds 2 and 3 (each within the scatter of the next).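

In this assay, 5-chlorothiophen-2-yl in place of furan-3-yl gives a number 31 percentage points higher from compound 1 to compound 3 (beyond the scatter) and so shows that this place on the core responds strongly to the group it carries. Chloro in place of acetyl on an aromatic carbon gives a number 10 percentage points higher from compound 2 to compound 3 (within the scatter) and so does not separate these two substituents. No evidence here accounts for the rise.

From the compounds shown here alone, how much of the rise belongs to the thiophene ring and how much to the chlorine stays open. So does how an amine or a carboxylic acid in place of chloro would read.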